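Swapping Chloro for Methoxy on the Second Aryl Ring

The source may report more compounds than this note shows. Statements on the series, on what has been measured and on what is new or still open speak of the compounds shown alone.

Compound 3 `CCC(=O)N1N=C(c2ccc(OC)cc2)CC1c1ccc(Cl)cc1` gives 832 nM in an assay on isolated protein for inhibition of Amine oxidase [flavin-containing] A (Bos taurus) (a lower number here means a stronger inhibitor, a higher number a weaker inhibitor), the second highest of the three numbers. Compound 1 `CCC(=O)N1N=C(c2ccccc2)CC1c1ccc(Cl)cc1` gives 200 nM, and compound 2 `CCC(=O)N1N=C(c2ccc(F)cc2)CC1c1ccc(Cl)cc1` gives 1410 nM; the steps of a 7.1-fold higher number from compound 1 to compound 2 (0.85 log units; beyond the scatter) and a 4.2-fold higher number from compound 1 to compound 3 (0.62 log units; beyond the scatter) are both modest weakenings, while a 1.7-fold lower number from compound 2 to compound 3 (0.23 log units; within the scatter) lies within the scatter. Compound 4 `CCC(=O)N1N=C(c2ccc(OC)cc2)CC1c1ccc(OC)cc1` differs from compound 3 by methoxy in place of chloro on an aromatic carbon. Among the measured compounds shown here, no measured step touches this ring, so the two steps on the other ring, each a modest weakening, are the only guide. A modest weakening, a 1.6-fold higher number from compound 3 to compound 4 (0.19 log units; within the scatter), is therefore expected, and compound 4 is estimated at 1300 nM, within 400 nM to 4000 nM.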

Compound 4, half-maximal inhibitory concentration: 1170 nM
The estimate for compound 4 lay 1.1-fold (0.05 log units) above the measured number; the measured number falls inside the stated range.
By their numbers in this assay, from the lowest: compound 1; then compounds 3, 4 and 2 (each within the scatter of the next).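

The first change shown on the ring bearing the chloro, 4-chlorophenyl to 4-methoxyphenyl, gives a 1.4-fold higher number from compound 3 to compound 4 (0.15 log units; within the scatter) in this assay. With methoxy already on the other ring, this position therefore takes methoxy in place of chloro with no change that can be read beyond the scatter. No measurement given bears on this result. From the compounds shown here alone, whether this holds with hydrogen in place of that other methoxy, as in compound 1, remains open. So does how an amine or a carboxylic acid would read at this position.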